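Fused bicyclic amides: urea replacing thiocarbamoyl at ring nitrogen

A few compounds are considered here, and "the series" means these few. Any claim that something is new, unique, unknown or untested is made for them only; others in the source may bear on it.

Measured so far in a functional assay on HL-60 cells (Homo sapiens) for antiproliferative activity, with a stated time of 24 h; on this read-out lower numbers stand for stronger inhibition and higher numbers for weaker inhibition:
compound 1 `NC(=O)c1c(NC(=O)c2ccccc2Cl)sc2c1CCN(Cc1ccccc1F)C2`: 21800 nM
compound 2 `NC(=O)c1c(NC(=O)c2ccccc2Cl)sc2c1CCN(C(=S)Nc1ccccc1)C2`: 5940 nM
compound 3 `NC(=O)c1c(NC(=O)c2ccccc2Cl)sc2c1CCN(C(=S)Nc1cccc3ccccc13)C2`: 13400 nM

Compound 2 gives the lowest number of the three in this assay. Its nearest neighbour is compound 3, a step of a 2.3-fold higher number from compound 2 to compound 3 (0.35 log units; beyond the scatter); the furthest is compound 1, from which compound 2 is reached by a 3.7-fold lower number from compound 1 to compound 2 (0.56 log units; beyond the scatter). Both steps are modest and both lie beyond the scatter.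

Compound 4 `NC(=O)c1c(NC(=O)c2ccccc2Cl)sc2c1CCN(C(=O)Nc1c(Cl)cccc1Cl)C2` has not been measured. Relative to compound 2 the change is a group of 11 heavy atoms (7 carbon, 1 nitrogen, 1 oxygen, 2 chlorine; one six-membered aromatic ring of carbon only) in place of a group of 9 heavy atoms (7 carbon, 1 nitrogen, 1 sulfur; one six-membered aromatic ring of carbon only), on an amine nitrogen in a ring.

Among the compounds with values here, no measured pair repeats this exact change. Within the data shown here, two steps bear on it indirectly. The step from compound 1 to compound 2 shows that a substituent of this kind on the ring nitrogen, carrying a hydrogen-bond donor and acceptor, lowers the number in this assay. The step from compound 2 to compound 3 shows that enlarging the aromatic part on the amide-type nitrogen, naphthalen-1-yl in place of phenyl, raises it. Among the measured compounds shown here, compound 4 keeps the donor and acceptor but adds two chlorine atoms to the aromatic ring, so a small rise in the number is expected, roughly a 1.4-fold higher number from compound 2 to compound 4 (0.16 log units; within the scatter), though the thio-to-oxo exchange has no precedent here and widens the range.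

For compound 4 the expected value in this assay is 8500 nM, within 2500 nM to 28000 nM.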

Compound 4, half-maximal inhibitory concentration: 17700 nM
Beside the measured number, compound 4's estimate is 2.1-fold (0.32 log units) below it; the range from low to high includes it.
By their numbers in this assay, from the lowest: compound 2; then compounds 3, 4 and 1 (each within the scatter of the next).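

In this assay, (2,6-dichlorophenyl)carbamoyl on the amine nitrogen in a ring gives a 3.0-fold higher number from compound 2 to compound 4 (0.47 log units; beyond the scatter), so the low number of compound 2 does not extend to every group at this place with 1 hydrogen-bond donor and 1 hydrogen-bond acceptor. The other new step, a 1.2-fold lower number from compound 1 to compound 4 (0.09 log units; within the scatter), leaves (2,6-dichlorophenyl)carbamoyl and 2-fluorobenzyl within the scatter of each other, so in this series the carbamoyl group alone brings no separation from the benzyl group. The step to compound 4 combines oxygen in place of sulfur with two chlorine atoms on the aromatic ring, and one value cannot divide the step between these two changes. No measurement bears on why the number moves with this change.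

The compounds shown leave open what the oxygen-for-sulfur exchange does alone, a question that phenylcarbamoyl at this place would address directly. Also open, from the compounds shown here alone, is whether a single chlorine, a methoxy group or an amine on the aromatic ring would bring the number back towards that of compound 2.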